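Ortho-substituted oxazoline ethers: bromo versus nitro

The compounds below may be only part of what the source reports. "The series", "measured", "known", "first", "only" and "open" are said of these compounds alone.

Measured in a functional assay on the whole organism for inhibition, with Rattus norvegicus as the target, read by paw edema, with a stated time of 30 min, at a dose of 80 mg/kg by the oral route; on this read-out lower numbers stand for a weaker effect and higher numbers for a stronger effect at the one dose given:
- compound 1, `Brc1ccccc1OCC1=NCCO1`, gives 62.8%
- compound 2, `Cc1cc(OCC2=NCCO2)ccc1Cl`, gives 77.1%

Compound 1 stands lowest of the two numbers in this assay; compound 2 lies higher by an amount beyond the usual scatter. Compound 3, `O=[N+]([O-])c1ccccc1OCC1=NCCO1`, is not yet measured. It differs from compound 1 by nitro in place of bromo on an aromatic carbon. Among the measured compounds shown here, no step between measured compounds covers such an exchange, so nothing measured points in either direction. The expected step of a number 2.8 percentage points lower from compound 1 to compound 3 (within the scatter) is none beyond the scatter. Compound 3 is estimated to give 60%, with a range from 42% to 78%.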

Compound 3, a percentage reported as inhibition, in the whole organism at one dose (the size of the read-out at that dose, not a potency): 50.5%
Beside the measured number, compound 3's estimate is 9.5 percentage points above it; low and high end bracket the measured number.
By their numbers in this assay, from the lowest: compound 3; then compound 1; then compound 2.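

In this assay, the aromatic carbon ortho to a group of 7 heavy atoms proves sensitive to its substituent: nitro in place of bromo gives a number 12.3 percentage points lower from compound 1 to compound 3 (beyond the scatter). Among the compounds shown here, this is the first exchange that can be read at a single place, and for this one pair bromo stands above nitro. No available measurement speaks to the origin of this step.

From the compounds shown here alone, whether this carbon responds to other groups remains open, since only bromo and nitro are compared there. An amine, a methoxy group or a carboxylic acid at the same carbon would show whether bromo or nitro lies near either end of the range.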